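The source may report more compounds than this note shows. Statements on the series, on what has been measured and on what is new or still open speak of the compounds shown alone.

Working notes on the series. In a functional assay on CEM-DNR-bulk cells (Homo sapiens), read by MTT assay, with a stated time of 72 h (on this read-out lower numbers stand for stronger inhibition and higher numbers for weaker inhibition), compound 1 `COc1nc(N)nc2c1c(-c1ccsc1)cn2[C@@H]1O[C@H](CO)[C@@H](O)[C@H]1O` returns only a limit, > 20000 nM. Compound 3 `CNc1ncnc2c1c(-c1cccs1)cn2[C@@H]1O[C@H](CO)[C@@H](O)[C@H]1O` likewise gives only a limit, > 20000 nM. Compound 2 `Cc1nc(N)c2c(-c3cccs3)cn([C@@H]3O[C@H](CO)[C@@H](O)[C@H]3O)c2n1` also reaches no number in this assay; its result is the limit > 20000 nM. Compound 2 therefore stands where the whole set stands: the limit of > 20000 nM in this assay, at which 3 of the 3 values shown sit. Among the measured compounds shown here, no step between measured compounds can be computed; no two of them differ in one place.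

Compound 4 `Cc1nc(N)c2c(-c3ccoc3)cn([C@@H]3O[C@H](CO)[C@@H](O)[C@H]3O)c2n1` remains to be measured in this assay. It differs from compound 2 in one place: furan-3-yl in place of thiophen-2-yl on an aromatic carbon. For the measured compounds named here, with every value in the set a limit and no measured step, the numbers give no direction for this change. The expected step is a step that the limit leaves unreadable from compound 2 to compound 4, that is, nothing beyond the scatter, and compound 4 is expected to sit at the limit as well. Compound 4 is estimated at 30000 nM in this assay, with a range from 10000 nM to 100000 nM.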

Compound 4, half-maximal inhibitory concentration: > 20000 nM
Compound 4: a limit, no number (the forecaster's own chance of this, stated with the estimate: 85%); the middle value is on the limit's open side.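

Compound 4, like compound 2, gives only a limit in this assay, so no step can be read between compound 2 and compound 4. The compounds shown leave open whether any change to the shared core yields a measurable value, as all results sit at one limit: the limit of > 20000 nM in this assay, at which 4 of the 4 values shown sit.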